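This account rests on a few compounds, and the source may have more. Where it says the series, first, only, none or still open, it means among the compounds named here.

Measured so far in a functional assay on HT-29 cells (Homo sapiens) for antiproliferative activity, read by sulforhodamine B assay, with a stated time of 48 h; on this read-out lower numbers stand for stronger inhibition and higher numbers for weaker inhibition:
- compound 1 `O=C1NCCN1c1ccc(S(=O)(=O)Nc2ccccc2)cc1`: 280 nM
- compound 2 `Cc1cccc(NS(=O)(=O)c2ccc(N3CCNC3=O)cc2)c1C`: 190 nM

Going by the values given here, compound 1 is one of only two measured compounds, and its value cannot be separated from that of compound 2. Among the compounds with values here, the single measured step is a 1.5-fold lower number from compound 1 to compound 2 (0.17 log units; within the scatter). It marks the two compounds as level in this assay, not as a real ranking.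

Compound 3 `CC(C)Cc1ccc(NS(=O)(=O)c2ccc(N3CCNC3=O)cc2)cc1` has not yet been measured. Its change from compound 1 is isobutyl in place of hydrogen on an aromatic carbon, with the isobutyl para to a large group.

Within the data shown here, only the step to compound 2 bears on this change. It also adds carbon substituents to the phenyl on the sulfonamide nitrogen, but the group and its place both differ, so the guidance is weak. Among the measured compounds shown here, no measured compound carries an isobutyl. For the measured compounds named here, with a 1.5-fold lower number from compound 1 to compound 2 (0.17 log units; within the scatter) as the only guide, no step beyond the scatter is expected, and no firm direction can be drawn, though a slightly lower number is the working assumption.

The expected step is a 1.4-fold lower number from compound 1 to compound 3 (0.15 log units; within the scatter). For compound 3 the estimated value is 200 nM, with an expected range from 70 nM to 600 nM.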

Compound 3, half-maximal inhibitory concentration: > 1000 nM
Compound 3: only a limit was reported; the forecaster's own chance of this, stated with the estimate: 3%; middle value at least 5.0-fold (0.69 log units) from the limit.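

In this assay, going by these compounds alone, isobutyl in place of hydrogen on an aromatic carbon, para to a large group, gives an at least 3.5-fold higher number from compound 1 to compound 3 (0.55 log units; beyond the scatter), the first step that lies beyond the scatter. For compound 3 the reported > 1000 nM is a limit of the assay and not a number, so the step has a lower bound only. The phenyl on the sulfonamide nitrogen does not take every carbon substituent alike: 2,3-dimethylphenyl in place of phenyl gives a 1.5-fold lower number from compound 1 to compound 2 (0.17 log units; within the scatter), whereas the isobutyl step is beyond the scatter.

The compounds shown leave open whether the group or its place decides the outcome; isobutyl appears in compound 3 alone, and the two substituted compounds differ in both group and place. As far as these compounds go, how a methyl, a methoxy or an amine at this same place would read in this assay also remains open, and these would show whether any substituent there is tolerated or whether the result is specific to isobutyl.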